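The compounds below may be only part of what the source reports. "The series", "measured", "known", "first", "only" and "open" are said of these compounds alone.

Compound 1 `CCCCNc1nc(N)nc(C)c1CCCc1ccccc1` and compound 2 `CCCCNc1nc(N)nc(C)c1CCCC(C)(C)O` share the same core and differ only in the group at the end of a saturated chain. In an assay on HEK293 cells for agonist activity at Toll-like receptor 8 (Homo sapiens), read by spectrophotometry (on this read-out lower numbers stand for an effect already at smaller amounts and higher numbers for an effect only at larger amounts of compound), compound 1 gives 749 nM, and compound 2 gives 1220 nM. Compound 2 stands at the higher of the two numbers, but the step of a 1.6-fold higher number from compound 1 to compound 2 (0.21 log units; within the scatter) is within the scatter, so the two compounds are not distinguishable on this read-out.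

Compound 3 `CCCCNc1nc(N)nc(C)c1CCCN1CCCC1` has not yet been measured in this assay. Its change from compound 2 is pyrrolidin-1-yl in place of 1-hydroxy-1-methylethyl on a saturated chain carbon, three bonds along the chain from an aromatic carbon. Among the measured compounds shown here, the only measured step at this place is a 1.6-fold higher number from compound 1 to compound 2 (0.21 log units; within the scatter), which exchanged phenyl for 1-hydroxy-1-methylethyl and stayed within the scatter; no measured compound carries pyrrolidin-1-yl there, so that step bears on the new change only in showing that this position has so far tolerated exchange without a move beyond the scatter.

For compound 3 no step beyond the scatter is expected, and the estimate is 1000 nM, within 300 nM to 3500 nM. The step this estimate means, a 1.2-fold lower number from compound 2 to compound 3 (0.09 log units; within the scatter), is expected to stay inside the scatter.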

Compound 3, half-maximal effective concentration: 110 nM
Beside the measured number, compound 3's estimate is 9.1-fold (0.96 log units) above it, outside the stated range (below it).
By their numbers in this assay, from the lowest: compound 3; then compounds 1 and 2 (each within the scatter of the next).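

The end of this saturated chain is not as indifferent as the earlier pair suggested: in this assay, pyrrolidin-1-yl gives an 11-fold lower number from compound 2 to compound 3 (1.04 log units; beyond the scatter) and also a 6.8-fold lower number from compound 1 to compound 3 (0.83 log units; beyond the scatter), whereas the exchange of phenyl for 1-hydroxy-1-methylethyl stayed within the scatter. Both new steps lie beyond the scatter. Compound 3 is the most potent of the three on this read-out, and the position can clearly respond to what is placed there. No measurement shown explains why this exchange has so large an effect.

The compounds shown leave open which part of the change matters, since pyrrolidin-1-yl brings in a nitrogen and a five-membered ring together: an open-chain amine such as dimethylamino at the same place, or cyclopentyl, which keeps the five-membered ring without the nitrogen, would help separate the two. From the compounds shown here alone, it also remains open how the result depends on the link to the core, which a longer or a shorter chain ending in pyrrolidin-1-yl would address.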